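Acetylation at a Third Hydroxyl of Compound 1

The compounds below may be only part of what the source reports. "The series", "measured", "known", "first", "only" and "open" are said of these compounds alone.

Measured so far:
compound 1 `C=C/C=C\C(C)C(OC(N)=O)[C@@H](C)[C@H](O)C(C)C/C(C)=C\C(C)[C@@H](O)[C@@H](C)/C=C\C(O)C[C@@H]1OC(=O)[C@H](C)[C@@H](OC(C)=O)[C@H]1C`, 3.8 nM
compound 2 `C=C/C=C\C(C)C(OC(N)=O)[C@@H](C)[C@H](O)C(C)C/C(C)=C\C(C)[C@@H](O)[C@@H](C)/C=C\C(C[C@@H]1OC(=O)[C@H](C)[C@@H](OC(C)=O)[C@H]1C)OC(C)=O`, 0.8 nM
compound 3 `C=C/C=C\C(C)C(OC(N)=O)[C@@H](C)[C@H](O)C(C)C/C(C)=C\C(C)[C@@H](OC(C)=O)[C@@H](C)/C=C\C(O)C[C@@H]1OC(=O)[C@H](C)[C@@H](OC(C)=O)[C@H]1C`, 164 nM

In a functional assay on A549 cells (Homo sapiens) for inhibition (a higher number here means a weaker inhibitor, a lower number a stronger inhibitor), compound 1 gives 3.8 nM, the second highest of the three numbers; compound 2 lies nearest, and compound 3 furthest from it. Compound 4 `C=C/C=C\C(C)C(OC(N)=O)[C@@H](C)[C@H](OC(C)=O)C(C)C/C(C)=C\C(C)[C@@H](O)[C@@H](C)/C=C\C(O)C[C@@H]1OC(=O)[C@H](C)[C@@H](OC(C)=O)[C@H]1C` differs from compound 1 in one place: acetyl in place of hydrogen on an oxygen on a saturated carbon.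

For the measured compounds named here, two measured steps bear on this change, and each is the same kind of change at a different hydroxy group. The step of a 4.8-fold lower number from compound 1 to compound 2 (0.68 log units; beyond the scatter) went in the favourable direction, whereas the step of a 43-fold higher number from compound 1 to compound 3 (1.64 log units; beyond the scatter) went strongly the other way. So the same replacement has already given opposite outcomes on this core, and the hydroxy group altered in compound 4 is a third one, for which no precedent exists. The step is therefore expected to lie beyond the scatter, most likely toward a higher number in this assay, but with wide uncertainty that also covers a lower number.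

For compound 4 the estimated value in this assay is 12 nM, within a range of 2.5 nM to 60 nM, which corresponds to an expected step of a 3.2-fold higher number from compound 1 to compound 4 (0.50 log units; beyond the scatter).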

Compound 4, half-maximal inhibitory concentration: 524 nM
Estimate against measurement, compound 4: 44-fold (1.64 log units) below; the whole stated range lies below it.
By their numbers in this assay, from the lowest: compound 2; then compound 1; then compound 3; then compound 4.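

In this assay, turning this third hydroxy group into an acetoxy group gives a 140-fold higher number from compound 1 to compound 4 (2.14 log units; beyond the scatter). That loss exceeds a 43-fold higher number from compound 1 to compound 3 (1.64 log units; beyond the scatter) and runs opposite to a 4.8-fold lower number from compound 1 to compound 2 (0.68 log units; beyond the scatter), so among the three hydroxy groups compared on the shared core, this one tolerates the change least. Two of the three acetylations now point toward a higher number, with compound 2 going against that trend, which shows that the outcome of this single replacement depends strongly on which hydroxy group carries it, and no measurement at hand explains the size of this step.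

The compounds shown leave open whether the loss at this position comes with losing the hydroxy hydrogen or with adding the acetyl group, as they carry only hydroxy or acetoxy here, and a methoxy group, a longer propionyl ester or an amine in its place could separate the two. Also open, from the compounds shown here alone, is how the acetoxy groups of compound 2 and compound 4 would act together on one molecule.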